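Furan Replacement in a Lipophilic Chain: Expected Cytotoxicity

The source may report more compounds than this note shows. Statements on the series, on what has been measured and on what is new or still open speak of the compounds shown alone.

Measured compounds:
- compound 1, `CC1=C(O)/C(=C/[C@H](C)CCC/C(C)=C/CCc2coc(Cc3ccoc3)c2)OC1=O`: 150000 nM
- compound 2, `CC1=C(O)/C(=C/[C@H](C)CC/C=C(/C)CCCc2coc(Cc3ccoc3)c2)OC1=O`: 140000 nM

Two compounds have been characterised in an ADME assay on L6 cells (Rattus norvegicus) for cytotoxicity, read by resazurin assay, with a stated time of 72 h; a higher number here means a weaker inhibitor, a lower number a stronger inhibitor. Compound 1 gives 150000 nM in this assay, and compound 2 gives 140000 nM. Compound 1 holds the highest of the two numbers, but its gap to compound 2 lies within the scatter, so the two values show no difference that can be read as order. Both compounds are weak inhibitors of L6 cell viability.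

Compound 3, `CC1=C(O)/C(=C/[C@H](C)CCC/C(C)=C/CCc2coc(CC3=CCN(CC(=O)O)C3=O)c2)OC1=O`, has not yet been measured in this assay. Relative to compound 1 it carries a group of 10 heavy atoms (6 carbon, 1 nitrogen, 3 oxygen; one five-membered non-aromatic ring with 1 hetero atom) in place of a group of 5 heavy atoms (4 carbon, 1 oxygen; one five-membered aromatic ring with 1 hetero atom), on a saturated chain carbon bound to an aromatic carbon. Within the data shown here, no step between measured compounds involves a change of this kind, so there is no measured precedent to draw on.

Given that compound 1 and compound 2 both sit at the weak end of this assay, the expectation for compound 3 is a number at a similar level, with no step beyond the scatter, and the step from compound 1 to compound 3 is estimated at a 1.1-fold higher number from compound 1 to compound 3 (0.05 log units; within the scatter). Compound 3 is expected to give about 170000 nM, within a range from 80000 nM to 350000 nM.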

Compound 3, half-maximal inhibitory concentration: > 200000 nM
Compound 3: no number, only a limit; the forecaster's own chance of this, stated with the estimate: 20%; middle value at least 1.1-fold (0.07 log units) away from the limit.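

In this assay compound 3 gives > 200000 nM, which is a limit of the assay and not a number. At the saturated chain carbon bound to an aromatic carbon, furan-3-yl gives way to a larger group with a five-membered non-aromatic ring and a hydrogen-bond donor, and this exchange comes with an at least 1.3-fold higher number from compound 1 to compound 3 (0.12 log units; that floor lies within the scatter), so this position takes a much larger group with no lower number appearing in this assay. Only the floor of that step is known, so it cannot be said whether the change moves the number beyond the scatter, and the reading ends at the top of the range reported: the limit of > 200000 nM in this assay, at which 1 of the 3 values shown sits.

The compounds shown leave open where the true value of compound 3 lies, and so how large the step really is. They also leave open how a phenyl ring or a simple amine at this same place would read in this assay, and whether the same exchange on the chain of compound 2 would behave in the same way.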